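Ethoxy in place of chloro, starting from a limit

The source may hold more compounds than are shown below. What is called first, only, known or untested is meant among the compounds shown, and "the series" means these compounds.

In an ADME assay on a cell-free system (plasma, Mus musculus) for metabolic stability, tested at 5 uM (a higher number here means that the compound lasts longer, a lower number that the compound disappears faster), compound 3 `CN(C)S(=O)(=O)c1cc(C(=O)O)c(Cl)cc1NCCCCCCCC(F)(F)F` gives > 2 h, which is a limit and not a number. Compound 1 `O=C(O)c1ccc(NCCCCCCCC(F)(F)F)c(S(=O)(=O)N2CCCC2)c1` likewise gives only a limit, > 2 h. Compound 2 `O=C(O)c1ccc(NCCCCCCCC(F)(F)F)c(S(=O)(=O)N2CCCCC2)c1` also gives only a limit, > 2 h. Among the measured compounds shown here, the only measured step is a step that the two limits leave unreadable from compound 1 to compound 2, and it concerns piperidin-1-yl in place of pyrrolidin-1-yl on a sulfonyl sulfur, not the present change. Compound 4 `CCOc1cc(NCCCCCCCC(F)(F)F)c(S(=O)(=O)N(C)C)cc1C(=O)O` differs from compound 3 by ethoxy in place of chloro on an aromatic carbon, ortho to a carboxy group. For compound 4 the expectation rests on (the limit of > 2 h in this assay, at which 3 of the 3 values shown sit). No step beyond the scatter is expected, and the estimated step is a step that the limit leaves unreadable from compound 3 to compound 4. The estimate for compound 4 is 3 h, with an expected range from 1.5 h to 6 h.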

Compound 4, half-life: > 2 h
Compound 4 ended at the assay's limit; the forecaster's own chance of this, stated with the estimate: 85%; the middle value lies beyond the limit too.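

Compound 3 and compound 4 both sit at a limit in this assay, and no step can be read between them. The compounds shown leave open how long each one actually lasts, and whether ethoxy in place of chloro makes any difference.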